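The compounds below may be only part of what the source reports. "The series", "measured", "known", "first", "only" and "open" are said of these compounds alone.

Three compounds share one core and differ only in the ring attached to the amide nitrogen. Compound 1 `O=C(CSc1nc2cccnc2[nH]1)Nc1cccc(Br)c1` gives 23% in an assay on isolated protein for inhibition of Ectonucleotide pyrophosphatase/phosphodiesterase family member 1 (Homo sapiens), tested at 10 uM; a lower number here means less inhibition, a higher number more inhibition at the concentration tested (going by the name of the read-out). Compound 2 `O=C(CSc1nc2cccnc2[nH]1)Nc1ccccc1` gives 30% in this assay, and compound 3 `O=C(CSc1nc2cccnc2[nH]1)Nc1ccccc1Cl` gives 19% in this assay. Compound 3 has the lowest of the three numbers: the step of a number 4 percentage points lower from compound 1 to compound 3 (within the scatter) stays within the scatter, and the step of a number 11 percentage points lower from compound 2 to compound 3 (beyond the scatter) is the only one that reaches beyond the scatter. The step of a number 7 percentage points higher from compound 1 to compound 2 (within the scatter) stays within the scatter.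

Compound 4 `Cc1ccc(NC(=O)CSc2nc3cccnc3[nH]2)c(Cl)c1` is not yet measured. It differs from compound 3 by methyl in place of hydrogen on an aromatic carbon. Among the compounds with values here, no measured pair adds a methyl, so the only guidance is the general picture: swapping a halogen for hydrogen moved the numbers by a number 7 percentage points higher from compound 1 to compound 2 (within the scatter) and by a number 11 percentage points lower from compound 2 to compound 3 (beyond the scatter), both small. A change of one carbon is therefore expected to give a step of about a number 1 percentage points lower from compound 3 to compound 4 (within the scatter) in this assay, not beyond the scatter. Compound 4 is estimated at 18%, in a range from 5% to 32%.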

Compound 4, a percentage reported as inhibition, at one concentration (the size of the read-out at that concentration, not a potency): 2%
For compound 4 the middle estimate is 16 percentage points above the measured one, outside the stated range (below it).
By their numbers in this assay, from the lowest: compound 4; then compounds 3, 1 and 2 (each within the scatter of the next, the first and the last beyond it).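

Adding a single carbon is enough to change the result here: methyl in place of hydrogen, on the aromatic carbon para to a large group and meta to a chloro group, gives a number 17 percentage points lower from compound 3 to compound 4 (beyond the scatter) in this assay. Within the data shown here, this is the first sign that this carbon of the ring matters, as compound 1, compound 2 and compound 3 all carry hydrogen there, and compound 4 retains only 2%. No measurement shown here explains the lower number.

Going by these compounds, it remains open whether the same fall would occur with methyl on this carbon in a ring without the chloro group. It is also unknown whether other groups at this carbon, such as an amine, a carboxylic acid or a longer chain, would lower the number as well or raise it.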